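Dimethylamino for Fluoro on a Dienone Scaffold

A few compounds are considered here, and "the series" means these few. Any claim that something is new, unique, unknown or untested is made for them only; others in the source may bear on it.

Compound 1 `O=C1/C(=C/c2ccc(F)cc2)CCC/C1=C\c1cccc([N+](=O)[O-])c1` gives 16300 nM in a functional assay on L1210 cells (Mus musculus) for cytotoxicity, with a stated time of 48 h (on this read-out higher numbers stand for weaker inhibition and lower numbers for stronger inhibition), the highest of the three numbers measured; compound 2 `O=C1/C(=C/c2ccc(F)cc2)CCC/C1=C\c1ccccc1[N+](=O)[O-]` gives 8400 nM and compound 3 `O=C1/C(=C/c2ccccc2)CCC/C1=C\c1ccccc1[N+](=O)[O-]` gives 4840 nM. Within the data shown here, the single measured step, a 1.7-fold lower number from compound 2 to compound 3 (0.24 log units; within the scatter), lies within the scatter. Compound 4 `CN(C)c1ccc(/C=C2\CCC/C(=C\c3cccc([N+](=O)[O-])c3)C2=O)cc1` differs from compound 1 by dimethylamino in place of fluoro on an aromatic carbon. Among the measured compounds shown here, no measured step places a dimethylamino group on the shared core, and the one step at this position, from fluoro to hydrogen, stayed within the scatter. Compound 4 is therefore expected to show no step beyond the scatter in this assay, with an estimated value of 12000 nM (range 4000 nM to 40000 nM), which amounts to an expected step of a 1.4-fold lower number from compound 1 to compound 4 (0.13 log units; within the scatter).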

Compound 4, half-maximal inhibitory concentration: 156000 nM
Beside the measured number, compound 4's estimate is 13-fold (1.11 log units) below it; the whole stated range lies below it.
By their numbers in this assay, from the lowest: compounds 3, 2 and 1 (each within the scatter of the next, the first and the last beyond it); then compound 4.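

In this assay, the aromatic carbon para to a large group proves sensitive to what it carries: dimethylamino in place of fluoro gives a 9.6-fold higher number from compound 1 to compound 4 (0.98 log units; beyond the scatter) and so moves clearly, whereas the fluoro-to-hydrogen change gave only a 1.7-fold lower number from compound 2 to compound 3 (0.24 log units; within the scatter) and left the number within the scatter. The data offer no measured explanation for this weaker inhibition.

The compounds shown leave open whether a smaller amine, such as amino or methylamino, or a methoxy group at this position would raise the number as far. On these data alone, it also remains open whether dimethylamino would act alike on the core of compound 2.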